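A few compounds are considered here, and "the series" means these few. Any claim that something is new, unique, unknown or untested is made for them only; others in the source may bear on it.

Measured so far:
compound 1 `NCCN[C@@H]1CC[C@@H](c2ccc(Cl)c(Cl)c2)c2ccccc21` gives 11000 nM in a functional assay on SGC-7901 cells (Homo sapiens) for antiproliferative activity, in the presence of a further agent that is not named here; a lower number here means a stronger inhibitor, a higher number a weaker inhibitor;
compound 2 `NCCN[C@@H]1CC[C@H](c2ccc(Cl)c(Cl)c2)c2ccccc21` gives 10700 nM in this assay.

Compound 1 sits beside compound 2, separated only by a 1.0-fold lower number from compound 1 to compound 2 (0.01 log units; within the scatter), a step resting on the fact that compounds 1 and 2 differ only in the configuration as drawn and within the scatter. Compound 3 `NCCCCN[C@@H]1CC[C@@H](c2ccc(Cl)c(Cl)c2)c2ccccc21` carries the change (2-aminoethyl in place of amino on a saturated chain carbon, two bonds along the chain from an amine nitrogen), that is, (2-aminoethyl)amino to (4-aminobutyl)amino. Going by the values given here, no measured step touches chain length, so the series gives no size for this step in this assay; the working expectation is none beyond the scatter. Compound 3 is therefore expected at 11000 nM, with range 4000 nM to 30000 nM. The expected step is no change at the digits printed from compound 1 to compound 3 (within the scatter).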

Compound 3, half-maximal inhibitory concentration: 6280 nM
Compound 3: middle estimate off by 1.8-fold (0.24 log units), on the high side; measured number inside the range.
By their numbers in this assay, from the lowest: compounds 3, 2 and 1 (each within the scatter of the next).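

Going by these compounds alone, the first step on chain length in this assay, (2-aminoethyl)amino to (4-aminobutyl)amino, reads a 1.8-fold lower number from compound 1 to compound 3 (0.24 log units; within the scatter). At this position, the 4-aminobutyl chain therefore holds the read-out within the scatter of the 2-aminoethyl chain. Nothing available bears on the reason for the size of this step.

Still open, going by these compounds, is whether a longer chain, such as 6-aminohexyl, would move the number beyond the scatter. Also open, on these data alone, is what a carboxylic acid at the chain end, in place of the amine, would do.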